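The source may report more compounds than this note shows. Statements on the series, on what has been measured and on what is new or still open speak of the compounds shown alone.

Measured compounds in a functional assay on HEK293 cells for agonist activity at Bombesin receptor subtype-3 (Mus musculus), read by luminescence and calcium flux, with a stated time of 10 min; a lower number here means that less compound is needed, a higher number that more compound is needed for the effect:
- compound 1 `CCC(C)(C)Cc1c[nH]c(CCc2ccc(-n3cccn3)cc2)n1` gives 113 nM
- compound 2 `CCC(C)(C)Cc1c[nH]c(CCc2ccc(-c3cccc(C#N)n3)cc2)n1` gives 115 nM
- compound 3 `CCC(C)(C)Cc1c[nH]c(CCc2ccc(-c3cnsc3)cc2)n1` gives 119 nM

All three share one core and differ only in the ring hung on the aromatic carbon. Compound 1 sits together with the other two: the steps of a 1.0-fold higher number from compound 1 to compound 2 (0.01 log units; within the scatter) and a 1.1-fold higher number from compound 1 to compound 3 (0.02 log units; within the scatter) are both within the scatter, as is a 1.0-fold higher number from compound 2 to compound 3 (0.01 log units; within the scatter).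

Compound 4 `CCC(C)(C)Cc1c[nH]c(CCc2ccc(-n3cncn3)cc2)n1` is not yet measured. Its difference from compound 1 is:
1H-1,2,4-triazol-1-yl in place of 1H-pyrazol-1-yl on an aromatic carbon

Every measured step bears on this, since each swaps the same group at the same place for another small aromatic ring. All three were within the scatter, and the change to compound 4 is of the same kind, so no step beyond the scatter is expected in this assay in either direction. The number expected for compound 4 is therefore 115 nM, with a range from 55 nM to 240 nM, which means an expected step of a 1.0-fold higher number from compound 1 to compound 4 (0.01 log units; within the scatter).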

Compound 4, half-maximal effective concentration: 121 nM
Estimate against measurement, compound 4: 1.1-fold (0.02 log units) below, and the stated range covers the measured number.
By their numbers in this assay, from the lowest: compounds 1, 2, 3 and 4 (each within the scatter of the next).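

The 1H-1,2,4-triazol-1-yl ring carries 3 hetero atoms and the 1H-pyrazol-1-yl ring carries 2, yet in this assay the swap gives a 1.1-fold higher number from compound 1 to compound 4 (0.03 log units; within the scatter), so one more ring nitrogen at this place leaves no readable mark. The new ring also sits level with the two other rings, with a 1.0-fold higher number from compound 3 to compound 4 (0.01 log units; within the scatter) and a 1.1-fold higher number from compound 2 to compound 4 (0.02 log units; within the scatter), so all four small aromatic rings on the carbon para to a large group now read alike in this assay. Nothing available here offers an explanation for this flat result.

The compounds shown leave open whether this place would tolerate a group that is not an aromatic ring, such as an amine, a carboxylic acid or a longer alkyl chain. They also leave open what plain hydrogen there would give.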